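Replacing But-2-en-1-yl with Benzyl on the Shared Core

The source may hold more compounds than are shown below. What is called first, only, known or untested is meant among the compounds shown, and "the series" means these compounds.

In an ADME assay on HEK293 cells (Homo sapiens) for inhibition, read by MTT assay, with a stated time of 3 days (on this read-out higher numbers stand for weaker inhibition and lower numbers for stronger inhibition), compound 1 `C=CCOc1cc(/C=C\c2cc(OC)c(OC)c(OC)c2)ccc1OC` gives 43500 nM, while compound 2 `C/C=C/COc1cc(/C=C\c2cc(OC)c(OC)c(OC)c2)ccc1OC` gives 135000 nM. Compound 2 therefore holds the higher of the two numbers, which means the weaker inhibition of this pair. Compound 3 `COc1ccc(/C=C\c2cc(OC)c(OC)c(OC)c2)cc1OCc1ccccc1` keeps the same core and alters a single group: phenyl in place of prop-1-en-1-yl on a saturated chain carbon bound to an oxygen on an aromatic ring. Put another way, but-2-en-1-yl gives way to benzyl.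

Among the measured compounds shown here, only one measured step bears on this change at the same place: a 3.1-fold higher number from compound 1 to compound 2 (0.49 log units; beyond the scatter). That modest step came with prop-1-en-1-yl in place of vinyl, and it does not test a phenyl group. Two compounds also set no trend. The expectation therefore stays close to compound 2, leaning slightly toward the lower number of compound 1 at 43500 nM, with no shift clearly beyond the scatter. The expected change is a 1.5-fold lower number from compound 2 to compound 3 (0.18 log units; within the scatter). Compound 3 is estimated at 90000 nM, with an expected range of 30000 nM to 250000 nM.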

Compound 3, half-maximal inhibitory concentration: 15000 nM
For compound 3 the middle estimate is 6.0-fold (0.78 log units) above the measured one, outside the stated range (below it).
By their numbers in this assay, from the lowest: compound 3; then compound 1; then compound 2.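

In this assay, among the compounds shown here, the position on a saturated chain carbon bound to an oxygen on an aromatic ring can move the number in both directions, not only upward as the single earlier step allowed: phenyl in place of prop-1-en-1-yl gives a 9.0-fold lower number from compound 2 to compound 3 (0.95 log units; beyond the scatter), and phenyl in place of vinyl gives a 2.9-fold lower number from compound 1 to compound 3 (0.46 log units; beyond the scatter). Both steps lie beyond the scatter, so among these three compounds the benzyl group on the shared core gives the strongest inhibition, and the number does not simply rise as the group on this carbon grows, since phenyl with 6 heavy atoms stands against prop-1-en-1-yl with 3. Nothing available explains why the aromatic ring and the two alkenyl groups differ in this way.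

The compounds shown leave open whether the lower number needs the aromatic ring itself, a question that a cyclohexyl group in place of phenyl would address. They also leave open how a pyridine ring, a methoxy group on the benzyl ring, or a longer saturated chain would read at this position.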